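This account rests on a few compounds, and the source may have more. Where it says the series, first, only, none or still open, it means among the compounds named here.

Compounds measured so far:
compound 1 `CC(C)C[C@H](N)c1cc(C(F)(F)F)ccc1N1CCN(C(=O)C(C)Cc2ccc(Cl)cc2)CC1` — 47 nM
compound 2 `CC(C)C[C@H](N)c1cc(F)ccc1N1CCN(C(=O)C(C)Cc2ccc(Cl)cc2)CC1` — 390 nM

Both were tested in an assay on HEK293 cells for displacement of a labelled ligand from Melanocortin receptor 4 (Homo sapiens); a higher number here means a weaker inhibitor, a lower number a stronger inhibitor. Compound 1 stands lowest of the two numbers; its nearest neighbour is compound 2, reached by an 8.3-fold higher number from compound 1 to compound 2 (0.92 log units; beyond the scatter). Compound 3 `CC(C)C[C@H](N)c1cc(C(F)(F)F)ccc1N1CCN(C(=O)COc2ccc([N+](=O)[O-])cc2)CC1` is not yet measured. It differs from compound 1 thus: (4-nitrophenoxy)methyl in place of 1-(4-chlorobenzyl)ethyl on a carbonyl carbon. For the measured compounds named here, the one measured step concerns a group on an aromatic carbon, not the carbonyl carbon, so no measured step bears on this change. With no guidance, a modest weakening is expected, a 3.2-fold higher number from compound 1 to compound 3 (0.50 log units; beyond the scatter). Compound 3 is therefore estimated at 150 nM, in the range 30 nM to 800 nM.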

Compound 3, inhibition constant: 3100 nM
Compound 3: middle estimate off by 21-fold (1.32 log units), on the low side; measured number above the stated range.
By their numbers in this assay, from the lowest: compound 1; then compound 2; then compound 3.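

At the carbonyl carbon, putting (4-nitrophenoxy)methyl in place of 1-(4-chlorobenzyl)ethyl gives a 66-fold higher number from compound 1 to compound 3 (1.82 log units; beyond the scatter), a large step, where the earlier change on the aromatic carbon was a modest one. Both groups hold one six-membered aromatic ring of carbon only, so the presence of such a ring alone does not preserve the binding of compound 1. Nothing at hand accounts for this loss.

Which part of the entering group carries the loss stays open, as the nitro group, the oxygen and the chlorine change together. Also open, on these data alone, is how an amine or a carboxylic acid in that group would fare on the carbonyl carbon.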